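Seven-carbon phenylalkyl ketones: acetyl to formyl on the oxazole

The compounds below may be only part of what the source reports. "The series", "measured", "known", "first", "only" and "open" are said of these compounds alone.

Compound 1 `O=C(CCCCCCc1ccccc1)c1nnc(-c2ccco2)s1`: in an assay on HEK-293T cells for inhibition of diacylglycerol lipase-alpha (Homo sapiens), read by colorimetric assay (on this read-out higher numbers stand for weaker inhibition and lower numbers for stronger inhibition), compound 1 gives > 10000 nM, a limit of the assay rather than a number.
Compound 2 `CC(=O)c1coc(C(=O)CCCCCCc2ccccc2)n1`: in this assay compound 2 gives 123 nM.

Two compounds share the seven-carbon phenylalkyl ketone chain and differ in the heteroaromatic ring attached to the carbonyl. Compound 1 reaches only a limit in this assay, as noted in the limit of > 10000 nM in this assay, at which 1 of the 2 values shown sits. Going by the values given here, compound 2 is the only compound with a numerical value in this assay, so its standing rests on one number alone and nothing here sets it against another measured compound.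

Compound 3 `O=Cc1coc(C(=O)CCCCCCc2ccccc2)n1` has not been measured in this assay. It differs from compound 2 by hydrogen in place of methyl on a carbonyl carbon; cut one bond further out, the change reads acetyl to formyl. Among the compounds with values here, no step between measured compounds is available to calibrate this change. A step of modest size is expected, most likely a small loss, though a result within the scatter of compound 2 would not be surprising; the expected step is a 1.8-fold higher number from compound 2 to compound 3 (0.25 log units; within the scatter). Compound 3 is therefore estimated at 220 nM in this assay, within a range of 50 nM to 900 nM.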

Compound 3, half-maximal inhibitory concentration: 1510 nM
Estimate against measurement, compound 3: 6.9-fold (0.84 log units) below, and the stated range ends below it.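

In this assay, going by these compounds alone, the change from acetyl to formyl gives a 12-fold higher number from compound 2 to compound 3 (1.09 log units; beyond the scatter), the first step that can be read at this place, and it lies beyond the scatter. It shows that the methyl on this carbonyl carbon is not a neutral part of compound 2: the loss of one carbon, with no change in hydrogen-bond donors, hydrogen-bond acceptors or net charge, is enough to separate compound 3 clearly from compound 2. Nothing shown here accounts for the size of this step, as the only point of evidence concerns a limit reached by another compound.

On these data alone, what remains open is whether the methyl is the best group on this carbonyl carbon, as an ethyl or a cyclopropyl group in its place, or a hydroxyl that would make a carboxylic acid, could go either way from compound 2. As far as these compounds go, it is also open whether the same step would appear with a shorter or longer phenylalkyl chain, since this single pair carries the seven-carbon chain alone.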